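Para group swap on aryl ring, cytotoxicity series

This account rests on a few compounds, and the source may have more. Where it says the series, first, only, none or still open, it means among the compounds named here.

Compound 1 `CCOC(=O)C12C(=O)OCC=C1COC2c1ccc(C(C)(C)C)cc1` carries tert-butyl on the aromatic ring. In a functional assay on A549 cells (Homo sapiens) for cytotoxicity, read by MTT assay (a lower number here means a stronger inhibitor, a higher number a weaker inhibitor), compound 1 reaches only the assay limit, > 1000000 nM, which is a limit and not a number (the limit of > 1000000 nM in this assay, at which 1 of the 2 values shown sits). Compound 2 `CCOC(=O)C12C(=O)OCC=C1COC2c1ccc(OC)cc1` carries methoxy at that place instead. In this assay compound 2 gives 9300 nM. Among the compounds with values here, compound 2 thus holds the only number so far; the other value in the set is a limit. Within the data shown here, the one measured step, an at least 100-fold lower number from compound 1 to compound 2 (2.03 log units; beyond the scatter), concerns the same aromatic position but a different pair of groups.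

Compound 3 `CCOC(=O)C12C(=O)OCC=C1COC2c1ccc(N(C)C)cc1` is the next member: dimethylamino in place of methoxy on an aromatic carbon. Among the measured compounds shown here, only the step from compound 1 to compound 2 bears on this position, and it was large, yet it swapped tert-butyl rather than methoxy. For the measured compounds named here, for the methoxy-to-dimethylamino change no direct precedent exists, so a step within the scatter is expected, a 1.2-fold lower number from compound 2 to compound 3 (0.07 log units; within the scatter). Compound 3 is estimated at 8000 nM, with a range from 2000 nM to 40000 nM.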

Compound 3, half-maximal inhibitory concentration: 89600 nM
Compound 3: the middle estimate sits 11-fold (1.05 log units) below what was measured, outside the stated range (above it).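

The aromatic position responds to more than the loss of tert-butyl: exchanging methoxy for dimethylamino, with no ring, no net charge and the same count of hydrogen-bond acceptors on either side, still gives a 9.6-fold higher number from compound 2 to compound 3 (0.98 log units; beyond the scatter) in this assay. Dimethylamino nevertheless keeps part of the gain over tert-butyl, with an at least 11-fold lower number from compound 1 to compound 3 (1.04 log units; beyond the scatter), and compound 2 holds the lowest number of the three. Compound 1 stands only as a limit and not a number: the limit of > 1000000 nM in this assay, at which 1 of the 3 values shown sits.

Going by these compounds, what a primary amine, a hydroxyl or a chlorine atom would give at this position stays open, as does whether the same order holds with these groups elsewhere on the aromatic ring. Three groups at a single position support no pattern reaching beyond these compounds.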